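A few compounds are considered here, and "the series" means these few. Any claim that something is new, unique, unknown or untested is made for them only; others in the source may bear on it.

Working notes on the series in a functional assay on M21 cells (Homo sapiens) for antiproliferative activity, read by sulforhodamine B assay, with a stated time of 48 h; on this read-out lower numbers stand for stronger inhibition and higher numbers for weaker inhibition. Compound 1 (`CC(C)(C)c1ccc(NS(=O)(=O)c2ccc(N3CCNC3=O)cc2)cc1`) gives > 1000 nM, which is a limit and not a number. For the measured compounds named here, compound 2 (`O=C1NCCN1c1ccc(S(=O)(=O)Nc2ccc(F)c(F)c2)cc1`) gives 220 nM, and compound 3 (`CCc1cccc(NS(=O)(=O)c2ccc(N3CCNC3=O)cc2)c1`) gives 82 nM, the lowest number so far.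

Compound 4 (`O=C1NCCN1c1ccc(S(=O)(=O)Nc2ccc(Cl)cc2)cc1`) carries 4-chlorophenyl in place of 3-ethylphenyl on a sulfonamide nitrogen. Going by the values given here, the one measured step at this place is modest: a 2.7-fold lower number from compound 2 to compound 3 (0.43 log units; beyond the scatter). On that step, a modest move to a higher number is expected when compound 4 gives up 3-ethylphenyl. The expected step is a 3.0-fold higher number from compound 3 to compound 4 (0.48 log units; beyond the scatter). The estimate for compound 4 is 250 nM, with an expected range of 90 nM to 800 nM.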

Compound 4, half-maximal inhibitory concentration: 90 nM
For compound 4 the middle estimate is 2.8-fold (0.44 log units) above the measured one; low and high end bracket the measured number.
By their numbers in this assay, from the lowest: compounds 3 and 4 (each within the scatter of the next); then compound 2. At a limit, above all of these: compound 1.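

The step of a 1.1-fold higher number from compound 3 to compound 4 (0.04 log units; within the scatter) shows that 4-chlorophenyl can stand in for 3-ethylphenyl on a sulfonamide nitrogen, so this place does not depend on an alkyl group. The 3,4-difluorophenyl group gives way to 4-chlorophenyl with a 2.4-fold lower number from compound 2 to compound 4 (0.39 log units; beyond the scatter). Chloro in place of tert-butyl gives an at least 11-fold lower number from compound 1 to compound 4 (1.04 log units; beyond the scatter), the largest step here, read from a limit and not from a number: the limit of > 1000 nM in this assay, at which 1 of the 4 values shown sits.

Open, as far as these compounds go, is whether 3-chlorophenyl matches 4-chlorophenyl, and whether an amine or a carboxylic acid on this ring holds the numbers of compound 3 and compound 4.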